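Aryl Exchange on the Ring Nitrogen: What Compound 3 May Give

A few compounds are considered here, and "the series" means these few. Any claim that something is new, unique, unknown or untested is made for them only; others in the source may bear on it.

Compound 1 `CN1C(=O)C(c2ccccc2)CC(c2ccccc2)C1=O` carries a methyl group on the amide-type nitrogen in a ring of its core. In a functional assay on the whole organism (strain Swiss albino) with Mus musculus as the target, in the maximal electroshock model, with a stated time of 2 h (on this read-out higher numbers stand for an effect only at larger amounts of compound and lower numbers for an effect already at smaller amounts), compound 1 gives 14.8 mg/kg. Compound 2 `O=C1C(c2ccccc2)CC(c2ccccc2)C(=O)N1c1cccc(Cl)c1` bears a 3-chlorophenyl group at that nitrogen. In this assay compound 2 reaches only the limit of the assay, > 100 mg/kg, and no number. Compound 2 therefore stands at the higher end of the two values shown, at the limit of > 100 mg/kg in this assay, at which 1 of the 2 values shown sits. Among the compounds with values here, the single measured step, an at least 6.7-fold higher number from compound 1 to compound 2 (0.82 log units; beyond the scatter), leads from the methyl compound to the aryl compound. Compound 3 `Cc1ccccc1N1C(=O)C(c2ccccc2)CC(c2ccccc2)C1=O` keeps an aryl group on that nitrogen: 2-methylphenyl in place of 3-chlorophenyl on an amide-type nitrogen in a ring. Within the data shown here, no measured step exchanges one aryl group for another, so the step from compound 1 to compound 2 bears on it only by showing that an aryl group on this nitrogen went with a limit. One therefore expects no step beyond the scatter in this assay from compound 2 to compound 3, a number no higher from compound 2 to compound 3 (the limit leaves the size open). Compound 3 is expected to sit near or at a limit as well. For compound 3 the estimate in this assay is 100 mg/kg, with a range from 40 mg/kg to 300 mg/kg.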

Compound 3, dose for half-maximal effect: 21.5 mg/kg
The estimate for compound 3 lay 4.7-fold (0.67 log units) above the measured number; measured number below the stated range.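

Within the data shown here, the exchange of 3-chlorophenyl for 2-methylphenyl on the amide-type nitrogen in a ring gives an at least 4.6-fold lower number from compound 2 to compound 3 (0.66 log units; beyond the scatter) in this assay and is the first measured step between two aryl groups at this position. Set against the methyl group, the 2-methylphenyl group gives a 1.5-fold higher number from compound 1 to compound 3 (0.16 log units; within the scatter) in the same read-out, so compound 1 and compound 3 cannot be told apart here, and an aryl group on this nitrogen is compatible with a measured effect at doses in the same range as those of the methyl compound. Among the compounds shown, the limit therefore belongs to the 3-chlorophenyl group of compound 2 alone and not to aryl groups on this nitrogen as a whole: the limit of > 100 mg/kg in this assay, at which 1 of the 3 values shown sits.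

The two aryl groups differ both in the atoms they carry and in where they carry them, so the compounds shown cannot separate the role of the chlorine from that of its place on the ring. On these data alone, how a 2-chlorophenyl group, a 3-methylphenyl group or an unsubstituted phenyl group would read at this nitrogen remains open, as does the reading of a phenyl group bearing an amine or a carboxylic acid.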